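A few compounds are considered here, and "the series" means these few. Any claim that something is new, unique, unknown or untested is made for them only; others in the source may bear on it.

Measured so far in a functional assay on HCT-15 cells (Homo sapiens) for inhibition, with a stated time of 72 h; a lower number here means a stronger inhibitor, a higher number a weaker inhibitor:
Compound 1 `CC1(c2ccccc2)CC(=O)C(C(CC(=O)c2ccc(-c3ccc(Br)cc3)cc2)c2ccccc2)=C(O)O1` gives 8590 nM.
Compound 2 `CCC1(c2ccccc2)CC(=O)C(C(CC(=O)c2ccc(-c3ccc(Br)cc3)cc2)c2ccccc2)=C(O)O1` gives 6710 nM.

Of these two numbers compound 2 holds the lower one, though its gap to compound 1 lies within the scatter. Compound 3 `CCCC1(c2ccccc2)CC(=O)C(C(CC(=O)c2ccc(-c3ccc(Br)cc3)cc2)c2ccccc2)=C(O)O1` is not yet measured; it differs from compound 2 by methyl in place of hydrogen on a saturated chain carbon, two bonds along the chain from a saturated ring carbon. Going by the values given here, the one step that bears on this, the same kind of change read as methyl to ethyl where this one is ethyl to propyl, gave a 1.3-fold lower number from compound 1 to compound 2 (0.11 log units; within the scatter). In this assay the step from compound 2 to compound 3 is therefore expected to be a 1.1-fold lower number from compound 2 to compound 3 (0.05 log units; within the scatter), no more than the scatter. Compound 3 is estimated at 6000 nM, within a range of 2500 nM to 15000 nM.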

Compound 3, half-maximal inhibitory concentration: > 10000 nM
Compound 3: a limit, no number; the forecaster's own chance of this, stated with the estimate: 3%; at least 1.6-fold (0.22 log units) between middle value and limit.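

In this assay compound 3, with propyl at this position, gives a limit rather than a number: the limit of > 10000 nM in this assay, at which 1 of the 3 values shown sits. From the compounds shown here alone, only floors can be read for its steps (an at least 1.4-fold higher number from compound 2 to compound 3 (0.17 log units; that floor lies within the scatter)) and (an at least 1.1-fold higher number from compound 1 to compound 3 (0.06 log units; that floor lies within the scatter)), so its true distance from either neighbour stays unknown. Even so, going from ethyl to propyl gives no sign of a stronger inhibitor, which the methyl and ethyl pair alone could not show.

Going by these compounds, whether a butyl chain, or a chain ending in an amine or a carboxylic acid, would give a measurable number here remains open.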